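Butoxy versus pentenyloxy on a chloro analogue

This account rests on a few compounds, and the source may have more. Where it says the series, first, only, none or still open, it means among the compounds named here.

Three compounds built on one shared core were tested in a functional assay on A2780 cells (Homo sapiens) for antiproliferative activity, read by MTT assay, with a stated time of 3 days; on this read-out higher numbers stand for weaker inhibition and lower numbers for stronger inhibition. Compound 1 `CCCCOC1(c2ccc(Br)cc2)SC=C(C)n2c1noc2=O` gives 82000 nM. Compound 2 `CC/C=C/COC1(c2ccc(Br)cc2)SC=C(C)n2c1noc2=O` gives 59000 nM. Compound 3 `CC/C=C/COC1(c2ccc(Cl)cc2)SC=C(C)n2c1noc2=O` gives 55000 nM. The three numbers lie close together: the change propyl in place of but-1-en-1-yl on a saturated chain carbon bound to an oxygen on a saturated carbon produced a 1.4-fold higher number from compound 2 to compound 1 (0.14 log units; within the scatter), and the change chloro in place of bromo on an aromatic carbon produced a 1.1-fold lower number from compound 2 to compound 3 (0.03 log units; within the scatter). Compound 3 therefore shows the lowest number of the three, but its gaps to compound 2 and to compound 1 are both within the scatter, so no order among them can be claimed.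

Compound 4 `CCCCOC1(c2ccc(Cl)cc2)SC=C(C)n2c1noc2=O` has not yet been measured in this assay. It differs from compound 3 by propyl in place of but-1-en-1-yl on a saturated chain carbon bound to an oxygen on a saturated carbon. The same change has already been made once, from compound 2 to compound 1, where it produced a 1.4-fold higher number from compound 2 to compound 1 (0.14 log units; within the scatter). The two pairs differ in their cores: compound 3 and compound 4 carry the change chloro in place of bromo on an aromatic carbon relative to compound 2 and compound 1, a difference that produced a 1.1-fold lower number from compound 2 to compound 3 (0.03 log units; within the scatter) between compound 2 and compound 3.

Because the earlier step of a 1.4-fold higher number from compound 2 to compound 1 (0.14 log units; within the scatter) was within the scatter, compound 4 is expected to give a number close to that of compound 3, with the estimated step of a 1.4-fold higher number from compound 3 to compound 4 (0.13 log units; within the scatter). Compound 4 is thus estimated at 75000 nM in this assay, with a range from 40000 nM to 140000 nM.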

Compound 4, half-maximal inhibitory concentration: 89000 nM
The estimate for compound 4 lay 1.2-fold (0.07 log units) below the measured number, and the stated range covers the measured number.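

In this assay, putting propyl in place of but-1-en-1-yl on the chloro core gave a 1.6-fold higher number from compound 3 to compound 4 (0.21 log units; within the scatter), and this step agrees with the one seen earlier on the bromo core: the same change on two cores in this assay, a 1.4-fold higher number (0.14 log units; within the scatter) from compound 2 to compound 1 and a 1.6-fold higher number (0.21 log units; within the scatter) from compound 3 to compound 4, 1.2-fold (0.07 log units) apart, within the scatter of two such steps Chloro in place of bromo on an aromatic carbon, read on the butoxy compounds, gave a 1.1-fold higher number from compound 1 to compound 4 (0.04 log units; within the scatter), which likewise agrees with the same change read on the pentenyloxy compounds: the same change on two cores in this assay, a 1.1-fold lower number (0.03 log units; within the scatter) from compound 2 to compound 3 and a 1.1-fold higher number (0.04 log units; within the scatter) from compound 1 to compound 4, 1.2-fold (0.07 log units) apart, within the scatter of two such steps The four compounds therefore show that, on these cores, each change gives a step within the scatter whichever core carries it, but they do not show that either change has a real effect that transfers from one core to the other, since a step of this size cannot be told apart from repeat measurement.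

On these data alone, whether a step beyond the scatter would also carry from one core to another remains open, as none of the steps here is large enough to test this. As far as these compounds go, it is also open whether a longer chain or an amine in place of propyl, or a nitrile in place of chloro on the aromatic carbon, would move the number beyond the scatter at all.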